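The source may report more compounds than this note shows. Statements on the series, on what has been measured and on what is new or still open speak of the compounds shown alone.

Measured so far:
- compound 1, `Cn1ncc([N+](=O)[O-])c1C(=O)Nc1ccc2nc(NC(=O)C3CCCCC3)sc2c1`, 0.026 ug/mL in a functional assay on WI-38 VA13 cells (Homo sapiens) for cytotoxicity; a lower number here means that less compound is needed, a higher number that more compound is needed for the effect
- compound 2, `N#Cc1cccc(C(=O)Nc2ccc3nc(NC(=O)C4CCCCC4)sc3c2)c1`, 0.52 ug/mL in this assay
- compound 3, `O=C(Nc1ccc2nc(NC(=O)C3CCCCC3)sc2c1)c1ccc(Cl)cc1Cl`, with only a limit in this assay

In this assay compound 3 reaches only the limit of the assay, > 4 ug/mL, and so gives no number; it sits at the limit of > 4 ug/mL in this assay, at which 1 of the 3 values shown sits. Compound 4, `CCCC(C)C(=O)Nc1ccc2nc(NC(=O)C3CCCCC3)sc2c1`, is not yet measured. The change is 1-methylbutyl in place of 2,4-dichlorophenyl on a carbonyl carbon. Going by the values given here, the measured steps that bear on this carbonyl substituent are an at least 150-fold higher number from compound 1 to compound 3 (2.18 log units; beyond the scatter) and an at least 7.6-fold higher number from compound 2 to compound 3 (0.88 log units; beyond the scatter), both large or at least modest and both ending at the limit; no measured step replaces an aryl group with an alkyl chain. The step of an at least 1.3-fold lower number from compound 3 to compound 4 (0.12 log units; that floor lies within the scatter) is therefore only an expectation with wide uncertainty. Compound 4 is expected to give about 3 ug/mL in this assay, plausibly between 0.4 ug/mL and 10 ug/mL.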

Compound 4, half-maximal effective concentration: 0.14 ug/mL
For compound 4 the middle estimate is 21-fold (1.33 log units) above the measured one; the whole stated range lies above it.
By their numbers in this assay, from the lowest: compound 1; then compound 4; then compound 2. At a limit, above all of these: compound 3.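

In this assay, going by these compounds alone, 1-methylbutyl, the only group here without a ring, shows that this carbonyl carbon needs no aromatic ring for a low number, and it falls within the span of the two measured aryl groups: a 3.7-fold lower number from compound 2 to compound 4 (0.57 log units; beyond the scatter) and a 5.4-fold higher number from compound 1 to compound 4 (0.73 log units; beyond the scatter). Replacing 2,4-dichlorophenyl gives an at least 28-fold lower number from compound 3 to compound 4 (1.45 log units; beyond the scatter), which is only a floor. Compound 3 stands at a limit and gives no number: the limit of > 4 ug/mL in this assay, at which 1 of the 4 values shown sits.

Going by these compounds, it remains open whether a straight or longer chain would hold the number seen with 1-methylbutyl. Also open, on these data alone, is how an amine or a carboxylic acid on this chain would read.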